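This account rests on a few compounds, and the source may have more. Where it says the series, first, only, none or still open, it means among the compounds named here.

Three compounds of the series have so far been run in a functional assay on Caco-2 cells (Homo sapiens) for inhibition, read by MTT assay, with a stated time of 48 h; a lower number here means a stronger inhibitor, a higher number a weaker inhibitor. Compound 2 `COc1cc(/C=N/Nc2nc(-c3ccc(Br)cc3)cs2)cc(Br)c1OC` gives 36200 nM. For compound 1 `COc1ccccc1-c1csc(N/N=C/c2cc(OC)c(OC)c(Br)c2Br)n1` the result is only a limit, > 100000 nM. For compound 3 `COc1cc(/C=N/Nc2nc(-c3cccc(Br)c3)cs2)c(Br)c(Br)c1OC` the result is likewise a limit, > 100000 nM. For the measured compounds named here, compound 2 therefore stands as the only actual number among the three; the other two sit at the limit of > 100000 nM in this assay, at which 2 of the 3 values shown sit. Going by the values given here, the single step between measured compounds, a step that the two limits leave unreadable from compound 1 to compound 3, is unreadable, so no measured step bears on the change to compound 4 `COc1cc(/C=N/Nc2nc(-c3ccc(F)c(F)c3)cs2)cc(Br)c1OC`, which differs from compound 2 by 3,4-difluorophenyl in place of 4-bromophenyl on an aromatic carbon. Without a readable precedent, no step beyond the scatter is expected in either direction, a 1.1-fold higher number from compound 2 to compound 4 (0.04 log units; within the scatter). Compound 4 is estimated at 40000 nM, within 10000 nM to 100000 nM, with a fair chance that this assay again returns only a limit.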

Compound 4, half-maximal inhibitory concentration: 21200 nM
Compound 4: middle estimate off by 1.9-fold (0.28 log units), on the high side; low and high end bracket the measured number.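

In this assay, for the compounds shown here, this change gives the first readable step: a 1.7-fold lower number from compound 2 to compound 4 (0.23 log units; within the scatter). On this aromatic carbon next to the ring nitrogen, 3,4-difluorophenyl and 4-bromophenyl therefore stand level, with two fluorines in place of one bromine and no shift beyond the scatter. The step from compound 1 to compound 3 still cannot be read, and actual numbers remain few: the limit of > 100000 nM in this assay, at which 2 of the 4 values shown sit.

Open, on these data alone, is whether an aminophenyl or carboxyphenyl group at this position would move the number beyond the scatter. Any reading beyond these two halogenated phenyl groups remains untested here.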